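Shortening a Branched Side Chain to Propyl

A few compounds are considered here, and "the series" means these few. Any claim that something is new, unique, unknown or untested is made for them only; others in the source may bear on it.

Compound 1 `C#CC(=O)N1C(c2cccc(F)c2)SC[C@@H]1C(=O)OCC`: 1400 nM
Compound 2 `C#CC(=O)N1C(C(CC)CCCC)SC[C@@H]1C(=O)OCC`: 1700 nM
Compound 3 `C#CC(=O)N1C(CC(C)CC(C)(C)C)SC[C@@H]1C(=O)OCC`: 1600 nM

In a functional assay on Huh-7 cells (Homo sapiens) for inhibition, read by sulforhodamine B assay (on this read-out lower numbers stand for stronger inhibition and higher numbers for weaker inhibition), compound 3 gives 1600 nM, the second highest of the three numbers; its gaps to compound 2 and to compound 1 both lie within the scatter, so none of the three can be set apart from the others. Compound 4 `C#CC(=O)N1C(CCCC)SC[C@@H]1C(=O)OCC` carries propyl in place of 1,3,3-trimethylbutyl on a saturated chain carbon bound to a saturated ring carbon. For the measured compounds named here, the only step between measured compounds that bears on this position is a 1.2-fold higher number from compound 1 to compound 2 (0.08 log units; within the scatter), an exchange of an aromatic group for a branched chain that stayed within the scatter; compounds 2 and 3, which carry two different alkyl chains, also sit within the scatter of each other. Shortening the chain is therefore expected to give no step beyond the scatter, a 1.1-fold higher number from compound 3 to compound 4 (0.03 log units; within the scatter). Compound 4 is estimated at 1700 nM, with a range from 800 nM to 3600 nM.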

Compound 4, half-maximal inhibitory concentration: 500 nM
Beside the measured number, compound 4's estimate is 3.4-fold (0.53 log units) above it; the whole stated range lies above it.
By their numbers in this assay, from the lowest: compound 4; then compounds 1, 3 and 2 (each within the scatter of the next).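

In this assay this position turns out to respond to the substituent after all: the step of a 3.2-fold lower number from compound 3 to compound 4 (0.51 log units; beyond the scatter) is matched by a 3.4-fold lower number from compound 2 to compound 4 (0.53 log units; beyond the scatter) and by a 2.8-fold lower number from compound 1 to compound 4 (0.45 log units; beyond the scatter) in the same direction. Compound 4, with the shorter unbranched chain, therefore stands clear of all three earlier compounds, which had stayed within the scatter of one another. Whether a still shorter chain such as ethyl, or a butyl chain ending in an amine, would hold this gain stays open, and nothing at hand explains the gain itself.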